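A halogen swap at the limit of the assay

This account rests on a few compounds, and the source may have more. Where it says the series, first, only, none or still open, it means among the compounds named here.

Compound 1 (`S=C(N/N=C/c1cccs1)Nc1ccc(Cl)cc1`) gives > 100000 nM
Compound 2 (`S=C(N/N=C/c1cccs1)Nc1cccnc1`) gives > 100000 nM
Compound 3 (`S=C(N/N=C/c1cccs1)Nc1cccc2ccccc12`) gives > 100000 nM

In a functional assay on HT-29 cells (Homo sapiens) for inhibition, read by sulforhodamine B assay, with a stated time of 48 h (on this read-out higher numbers stand for weaker inhibition of growth and lower numbers for stronger inhibition of growth), compound 1 gives > 100000 nM (a limit of the assay, not a number). All three compounds stand at the limit of > 100000 nM in this assay, at which 3 of the 3 values shown sit, and so none has an exact value. Compound 4 (`S=C(N/N=C/c1cccs1)Nc1ccc(Br)cc1`) differs from compound 1 in one place (bromo in place of chloro on an aromatic carbon): bromo in place of chloro on an aromatic carbon. Within the data shown here, no measured pair shows such a swap. With compound 1 known only by its limit > 100000 nM as a guide, no step beyond the scatter is expected in this assay for this change. The step expected is a number no higher from compound 1 to compound 4 (the limit leaves the size open) and it stays within the scatter. Expected for compound 4 is 100000 nM with a range from 40000 nM to 250000 nM as estimated.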

Compound 4, concentration for 50% growth inhibition: 17700 nM
Compound 4: the middle estimate sits 5.6-fold (0.75 log units) above what was measured; the measured number lies below the stated range.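

In this assay this place on the ring responds to the halogen: bromo in place of chloro gives an at least 5.6-fold lower number from compound 1 to compound 4 (0.75 log units; beyond the scatter) and so brings the first exact value among the compounds shown. A single heavy atom at this position is therefore enough to move the series off its limit. As far as these compounds go, the full size of the step remains unknown, because compound 1 is known only by a limit: the limit of > 100000 nM in this assay, at which 3 of the 4 values shown sit.

The compounds shown leave open whether iodo or fluoro at this position would lower the number further, and whether an amine or a carboxylic acid there would keep any of the growth inhibition.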